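The source may hold more compounds than are shown below. What is called first, only, known or untested is meant among the compounds shown, and "the series" means these compounds.

Working notes on the series. Compound 1 `Nc1cc(N)c2nc(-c3ccccc3)c(Oc3ccc(Cl)c(Cl)c3)nc2c1` carries a 3,4-dichlorophenoxy group on the shared core. In a functional assay on NCI-H226 cells (Homo sapiens) for inhibition, read by sulforhodamine B assay, with a stated time of 48 h (a lower number here means that less compound is tolerated, a higher number that more compound is tolerated), compound 1 gives only a limit, < 100000 nM, and no number. Two further members, compound 2 `COc1ccc(CNc2nc3cc(N)cc(N)c3nc2-c2ccccc2)cc1OC` and compound 3 `COc1cc(CNc2nc3cc(N)cc(N)c3nc2-c2ccccc2)cc(OC)c1OC`, carry another group in that position. In this assay compound 2 gives 64600 nM. For compound 3 only a limit is known in this assay, < 50200 nM. Within the data shown here, the one measured step between neighbours, an at least 1.2-fold lower number from compound 2 to compound 3 (0.10 log units; that floor lies within the scatter), is a floor that sits within the scatter and teaches little; the evidence on it is itself a limit, (the limit of < 50200 nM in this assay, at which 1 of the 3 values shown sits), as is the standing of compound 1, (the limit of < 100000 nM in this assay, at which 1 of the 3 values shown sits).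

Compound 4 `Nc1cc(N)c2nc(-c3ccccc3)c(Sc3ccc(Cl)c(Cl)c3)nc2c1` differs from compound 1 by (3,4-dichlorophenyl)sulfanyl in place of 3,4-dichlorophenoxy on an aromatic carbon. Among the measured compounds shown here, no measured step bears directly on this exchange; the step from compound 2 to compound 3 concerns a methoxy group elsewhere and is only a floor within the scatter. With compound 1 itself sitting at a limit in this assay, no step beyond the scatter is expected from the exchange, and the expected step that the limit leaves unreadable from compound 1 to compound 4 is put close to none. Compound 4 is estimated at 60000 nM in this assay, with a range from 15000 nM to 100000 nM, and a real chance that only a limit is reported again.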

Compound 4, concentration lethal to 50% of the cells: < 100000 nM
Compound 4: only a limit was reported; the forecaster's own chance of this, stated with the estimate: 50%; the middle value lies beyond the limit too.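

Compound 1 and compound 4 both stand only at a limit in this assay, so no step can be read for (3,4-dichlorophenyl)sulfanyl in place of 3,4-dichlorophenoxy: the limit of < 100000 nM in this assay, at which 2 of the 4 values shown sit.

The compounds shown leave open whether this exchange on the shared core changes the read-out in this assay at all.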